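The source may hold more compounds than are shown below. What is called first, only, known or untested is meant among the compounds shown, and "the series" means these compounds.

Three hydroxamic acids have been examined in an ADME assay on PBMC cells (Homo sapiens) for cytotoxicity, with a stated time of 72 h (on this read-out higher numbers stand for weaker inhibition and lower numbers for stronger inhibition), and each of them stopped at the edge of what the assay can report. Compound 1 `O=C(NO)c1ccc(Cn2nnc(-c3ncccn3)n2)cc1` gives > 1000 nM in this assay, which is a limit and not a number. Compound 3 `Cn1c(Sc2ccc(C(=O)NO)cc2)nnc1-c1cccs1` likewise gives only the limit > 1000 nM in this assay. Compound 2 `O=C(NO)c1cc(F)c(Cn2nnc(-c3ccccn3)n2)c(F)c1`, the starting point of the step followed here, also reaches only the limit > 1000 nM in this assay, so that compound 2 stands level with the other two, all three sitting at the limit of > 1000 nM in this assay, at which 3 of the 3 values shown sit.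

Compound 4 `O=C(NO)c1cc(F)c(Cn2nnc(-c3ccco3)n2)c(F)c1` differs from compound 2 in one place, (furan-2-yl in place of pyridin-2-yl on an aromatic carbon). For the measured compounds named here, no step between two measured compounds is available to gauge such a change, and the shared ring that bears the group has not been varied among measured compounds. The change from compound 2 to compound 4 in this assay is therefore expected to stay within the scatter, as a step that the limit leaves unreadable from compound 2 to compound 4. Compound 4 is accordingly estimated at 3000 nM in this assay, with a range from 1000 nM to 30000 nM, and most probably another limit rather than a number.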

Compound 4, half-maximal inhibitory concentration: > 1000 nM
Compound 4 gave a limit, no number; the forecaster's own chance of this, stated with the estimate: 85%; the middle value does not contradict the limit.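

Compound 2 and compound 4 both stop at a limit rather than a number, so no step can be read between them in this assay: the limit of > 1000 nM in this assay, at which 4 of the 4 values shown sit.

The compounds shown leave open how far any of the four lies from that limit, and whether furan-2-yl in place of pyridin-2-yl changes the read-out at all.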